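The source may report more compounds than this note shows. Statements on the series, on what has been measured and on what is new or still open speak of the compounds shown alone.

Compound 1 `COc1ccc(-c2cc3[nH]cnc3c(C#N)n2)cc1C(F)(F)F`: 339 nM
Compound 2 `N#Cc1nc(-c2ccc(OCCCO)c(C(F)(F)F)c2)cc2[nH]cnc12`: 63 nM
Compound 3 `CCOc1ccc(-c2cc3c(ncn3CCN(C)C)c(C#N)n2)cc1C(F)(F)F`: 32 nM

All three were tested in an assay on isolated protein for inhibition of cathepsin S (Homo sapiens), read by fluorescence; a lower number here means a stronger inhibitor, a higher number a weaker inhibitor. Compound 3 gives the lowest of the three numbers; against compound 2 the gap is within the scatter, against compound 1 it is beyond it. Compound 4 `CCOc1ccc(-c2cc3c(ncn3CCCN(C)C)c(C#N)n2)cc1C(F)(F)F` differs from compound 3 by (dimethylamino)methyl in place of dimethylamino on a saturated chain carbon, two bonds along the chain from an aromatic nitrogen. Among the measured compounds shown here, no measured step covers this exact change. For the measured compounds named here, the only step on record, a 5.4-fold lower number from compound 1 to compound 2 (0.73 log units; beyond the scatter), concerns a different chain, the one bound to an oxygen on an aromatic ring, so it says little about lengthening the chain on the aromatic nitrogen. Going by the values given here, with no direct precedent, compound 4 is expected to sit close to compound 3, with a step of a 1.1-fold lower number from compound 3 to compound 4 (0.03 log units; within the scatter) that stays within the scatter. The estimate for compound 4 in this assay is 30 nM, between 12 nM and 80 nM.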

Compound 4, half-maximal inhibitory concentration: 27 nM
Compound 4: the middle estimate sits 1.1-fold (0.05 log units) above what was measured; the measured number falls inside the stated range.
By their numbers in this assay, from the lowest: compounds 4, 3 and 2 (each within the scatter of the next, the first and the last beyond it); then compound 1.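

In this assay the chain on the aromatic nitrogen gets its first direct test: replacing 2-(dimethylamino)ethyl with 3-(dimethylamino)propyl gives a 1.2-fold lower number from compound 3 to compound 4 (0.07 log units; within the scatter). The earlier step concerned only the chain on the oxygen, whereas this one shows that adding a single chain carbon here leaves the two numbers indistinguishable. No evidence on hand explains this result.

Open, as far as these compounds go, is whether a still longer chain would also fit at this position. So is whether a morpholine or a carboxylic acid at the chain end would keep the number in this range.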